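Returning from a Urea to a Plain Amide

The compounds below may be only part of what the source reports. "The series", "measured", "known", "first", "only" and "open" are said of these compounds alone.

Of the compounds shown here, two on a shared core have been measured in a functional assay on UACC-62 cells (Homo sapiens) for inhibition, read by sulforhodamine B assay, with a stated time of 48 h; a higher number here means that more compound is tolerated, a lower number that less compound is tolerated. Compound 1 `COc1cc(-c2nn(-c3cccc(NC(=O)c4ccc(Cl)c(C(F)(F)F)c4)c3)cc2-c2ccncc2)ccc1Cl` reaches the limit of this assay, > 32500 nM. Compound 2 `COc1cc(-c2nn(-c3cccc(NC(=O)Nc4ccc(Cl)c(C(F)(F)F)c4)c3)cc2-c2ccncc2)ccc1Cl` gives 11600 nM in this assay. Among the measured compounds shown here, it is the only true number in the set. For the measured compounds named here, the one measured step is an at least 2.8-fold lower number from compound 1 to compound 2 (0.44 log units; beyond the scatter), and its size is known only as a bound, given (the limit of > 32500 nM in this assay, at which 1 of the 2 values shown sits).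

Compound 3 `COc1cc(-c2nn(-c3cccc(NC(=O)c4ccccc4)c3)cc2-c2ccncc2)ccc1Cl` differs from compound 2 by phenyl in place of (4-chloro-3-(trifluoromethyl)phenyl)amino on a carbonyl carbon. This undoes the change that produced the step from compound 1 to compound 2, turning the urea back into an amide, and at the same time strips the chlorine and trifluoromethyl from the aromatic ring. Compound 1, the amide with the substituted ring, sat at the limit, so the amide with a bare ring is expected to move back upward, with a 2.6-fold higher number from compound 2 to compound 3 (0.41 log units; beyond the scatter) as the estimated step. For compound 3 the estimate in this assay is 30000 nM, within a range from 12000 nM to 80000 nM, with a real chance that only a limit is reported.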

Compound 3, concentration lethal to 50% of the cells: > 100000 nM
Compound 3 was reported as a limit (the forecaster's own chance of this, stated with the estimate: 55%); middle value at least 3.3-fold (0.52 log units) from the limit.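

Among the compounds shown here, on the carbonyl carbon, phenyl in place of (4-chloro-3-(trifluoromethyl)phenyl)amino gives an at least 8.6-fold higher number from compound 2 to compound 3 (0.93 log units; beyond the scatter) in this assay, so the urea of compound 2 remains the only one of the three compounds with a true number. Compound 3 is reported as a limit, which makes the size of this step a bound and not a measurement: the limit of > 100000 nM in this assay, at which 1 of the 3 values shown sits. The change also removes the amino nitrogen, the chlorine and the trifluoromethyl in a single move, so this step alone cannot assign the difference to any one of them.

As far as these compounds go, the step between the two amides, compound 1 and compound 3, cannot be read because both are reported only as limits, and whether the chlorine and trifluoromethyl make any difference on an amide therefore stays unknown: the limit of > 32500 nM in this assay, at which 1 of the 3 values shown sits. Also open is how a urea ending in a bare phenyl would read, which would separate the amino nitrogen from the ring substituents, and how an amine or a carboxylic acid on that ring would behave.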